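From hydroxymethyl to trifluoromethyl in compound 3

The source may report more compounds than this note shows. Statements on the series, on what has been measured and on what is new or still open speak of the compounds shown alone.

Compound 1 `CNC(=O)c1cc(N)c(Nc2ccc(C#N)cc2)cc1Oc1c(C)cc(CCC#N)cc1C` gives 0.928 h
Compound 2 `Cc1cc(CCC#N)cc(C)c1Oc1cc(Nc2ccc(C#N)cc2)c(N)cc1CO` gives 0.348 h

In an in vitro ADME assay on microsomes from liver (Homo sapiens) for metabolic stability, tested at 1 uM (on this read-out lower numbers stand for a shorter-lived compound and higher numbers for a longer-lived compound), compound 2 stands lowest of the two at 0.348 h and compound 1 lies above it. Compound 3 `Cc1cc(CCC#N)cc(C)c1Oc1cc(Nc2ccc(C#N)cc2)c(N)cc1C(F)(F)F` is the next to be measured, and it carries trifluoromethyl in place of hydroxymethyl on an aromatic carbon. Among the compounds with values here, only one measured step touches this same carbon, hydroxymethyl replacing methylcarbamoyl (a 2.7-fold lower number from compound 1 to compound 2 (0.43 log units; beyond the scatter)), and it was modest. Trifluoromethyl itself is untested here, so the evidence is thin. Compound 2 (0.348 h) is the lower of the pair, so a modest rise is expected once its hydroxymethyl is gone, though the rise could stay within the scatter. The estimate is a step of similar size (a 2.0-fold higher number from compound 2 to compound 3 (0.30 log units; within the scatter)). Compound 3 is expected at 0.7 h (estimated range 0.3 h to 1.6 h).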

Compound 3, half-life: 0.928 h
Compound 3: the middle estimate sits 1.3-fold (0.12 log units) below what was measured, within the range that was stated.
By their numbers in this assay, from the lowest: compound 2; then compounds 1 and 3 (each within the scatter of the next).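

In this assay, the carbon para to the (4-cyanophenyl)amino group has now carried three different groups, and trifluoromethyl in place of hydroxymethyl gives a 2.7-fold higher number from compound 2 to compound 3 (0.43 log units; beyond the scatter). Trifluoromethyl in place of methylcarbamoyl gives no change at the digits printed from compound 1 to compound 3 (within the scatter), so the two groups cannot be told apart here, and among the three compounds only hydroxymethyl, in compound 2, stands apart with a shorter half-life. Nothing measured here explains why hydroxymethyl differs from the other two groups.

The compounds shown leave open where a carboxylic acid, a plain methyl or a longer chain ending in a hydroxyl would fall on this carbon. They also leave open whether the gap between hydroxymethyl and the other two groups would persist if another part of the shared core changed.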